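Ethyl ester in place of a furoyl ketone

The source may report more compounds than this note shows. Statements on the series, on what has been measured and on what is new or still open speak of the compounds shown alone.

Measured compounds:
compound 1 `CC1(C)S[C@@H]2/C(=C\C(=O)c3ccco3)C(=O)N2[C@H]1C(=O)OC(c1ccccc1)c1ccccc1` — 45500 nM
compound 2 `CC1(C)[C@H](C(=O)OC(c2ccccc2)c2ccccc2)N2C(=O)/C(=C/C(=O)c3ccccc3)[C@H]2S1(=O)=O` — 19500 nM

Both compounds were tested in a functional assay on HT-1080 cells (Homo sapiens) for cytotoxicity, read by MTT assay, with a stated time of 48 h; on this read-out lower numbers stand for stronger inhibition and higher numbers for weaker inhibition. In this assay compound 1 gives 45500 nM, the highest of the two numbers recorded, so it shows the weakest inhibition of the pair. Compound 2 gives 19500 nM, a lower number, and the gap between the two values is wider than the usual scatter of repeated measurements. Among the measured compounds shown here, the two compounds differ in more than one place, so no single structural step can be tied to that gap.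

Compound 3 `CCOC(=O)/C=C1/C(=O)N2[C@@H]1SC(C)(C)[C@@H]2C(=O)OC(c1ccccc1)c1ccccc1` has not yet been measured in this assay. It differs from compound 1 at the carbonyl carbon attached to the double-bonded chain carbon: ethoxy in place of furan-2-yl on a carbonyl carbon. Nothing in the measured pair shows what this exchange does, so the expectation rests on compound 1 alone. From compound 1 the step is expected to be small, roughly a 1.1-fold higher number from compound 1 to compound 3 (0.04 log units; within the scatter), with no clear direction beyond the scatter. Compound 3 is therefore estimated at 50000 nM, within a range from 15000 nM to 160000 nM.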

Compound 3, half-maximal inhibitory concentration: 25100 nM
Compound 3: the middle estimate sits 2.0-fold (0.30 log units) above what was measured; measured number inside the range.
By their numbers in this assay, from the lowest: compounds 2, 3 and 1 (each within the scatter of the next, the first and the last beyond it).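

In this assay, ethoxy in place of furan-2-yl on a carbonyl carbon gives a 1.8-fold lower number from compound 1 to compound 3 (0.26 log units; within the scatter), so at this position the numbers of the two compounds cannot be told apart, and the furan ring is not needed to keep the number at the level of compound 1. The group that enters has no ring and fewer heavy atoms than the one that leaves, while the count of hydrogen-bond acceptors stays the same, so this single step shows that a ketone bearing an aromatic ring and an ethyl ester sit here with no readable difference. Nothing available explains this lack of a clear difference.

On these data alone, whether any group at this place can shift the number beyond the scatter stays open, for instance an amine, a carboxylic acid or a longer chain in place of ethoxy. Compound 2 differs from compound 1 in more than one place, so it cannot show whether the same exchange would behave alike elsewhere in the series.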